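The source may hold more compounds than are shown below. What is called first, only, known or untested is meant among the compounds shown, and "the series" means these compounds.

Compound 2 `Cc1sc2ccccc2c1C1C=CN=CN1` gives 3 mg/kg in a functional assay on the whole organism with Mus musculus as the target, with a stated time of 15 min; on this read-out higher numbers stand for an effect only at larger amounts of compound and lower numbers for an effect already at smaller amounts. It stands level with compound 3 `Cc1sc2cccc(F)c2c1C1C=CN=CN1`, which gives 3 mg/kg, the two together holding the lowest numbers of the three measured, while compound 1 `Cc1sc2c(F)cccc2c1C1C=CN=CN1` sits furthest away at 10 mg/kg. The step of a 3.3-fold lower number from compound 1 to compound 2 (0.52 log units; beyond the scatter) is the only one beyond the scatter; the step of no change at the digits printed from compound 2 to compound 3 (within the scatter) stays within it. Compound 4 `Cc1sc2ccccc2c1C1C=CN=CN1C` differs from compound 2 by methyl in place of hydrogen on an amine nitrogen in a ring. Both measured steps concern a fluoro on an aromatic carbon rather than the amine nitrogen in a ring, so neither bears directly on this change, and the set offers no measured guide to a methyl at that position. With nothing to point either way, the expected step of a 1.3-fold higher number from compound 2 to compound 4 (0.12 log units; within the scatter) in this assay is taken as none beyond the scatter, with a broad allowance on both sides. Compound 4 is therefore estimated at 4 mg/kg in this assay, within a range from 1 mg/kg to 15 mg/kg.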

Compound 4, minimum effective dose: 30 mg/kg
Compound 4: the middle estimate sits 7.5-fold (0.88 log units) below what was measured, outside the stated range (above it).
By their numbers in this assay, from the lowest: compounds 2 and 3 (each within the scatter of the next); then compound 1; then compound 4.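

In this assay, among these compounds, methyl in place of hydrogen on the amine nitrogen in a ring gives a 10-fold higher number from compound 2 to compound 4 (1.00 log units; beyond the scatter), a larger step than a 3.3-fold lower number from compound 1 to compound 2 (0.52 log units; beyond the scatter), the largest seen among the earlier compounds. This shows that the read-out responds strongly to a change at this nitrogen, next to the ring atom that bears a large group, which the fluoro steps on the aromatic carbon could not show. Nothing measured here accounts for the size of this step.

The compounds shown carry only hydrogen or methyl on this nitrogen, so it remains open whether an ethyl, an acetyl or a hydroxyethyl group would give a similar rise. On these data alone, it also remains open whether methyl there would give a like step on the fluoro compounds.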